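The source may hold more compounds than are shown below. What is called first, only, known or untested is meant among the compounds shown, and "the series" means these compounds.

Measured so far:
- Compound 1, `Cc1ccc(C(=O)Nc2ncc(-c3ccccc3)o2)cc1`: 26000 nM in a toxicity assay on THP-1 cells (Homo sapiens) for inhibition; on this read-out higher numbers stand for lower toxicity in this test and lower numbers for higher toxicity in this test
- Compound 2, `O=C(Nc1ncc(-c2ccccc2)o1)c1ccc(F)cc1`: 17000 nM in this assay
- Compound 3, `COc1ccc(-c2cnc(NC(=O)c3cccc(C)c3)n2C)cc1`: > 100000 nM in this assay

The value of compound 3 is a limit of the assay, not a number. Compounds 1 and 2 share one core and differ by fluoro in place of methyl on an aromatic carbon; the step is a 1.5-fold lower number from compound 1 to compound 2 (0.18 log units; within the scatter), within the scatter. Compound 3 carries another core; the difference between the two cores is not broken down here.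

Compound 4, `COc1ccc(-c2cnc(NC(=O)c3cccc(F)c3)n2C)cc1`, is not yet measured. It differs from compound 3 by fluoro in place of methyl on an aromatic carbon. The place of the change in compound 2 reads para to a large group, in compound 4 it reads meta to a large group, so this is the same kind of change, not the same change. Given that the one measured instance of this change stayed within the scatter, the step from compound 3 to compound 4 in this assay is expected to be about a number no higher from compound 3 to compound 4 (the limit leaves the size open), resting on compound 3 sitting at the limit of > 100000 nM in this assay, at which 1 of the 3 values shown sits. For compound 4 the expected value is therefore 100000 nM, in the range 40000 nM to 250000 nM, and most likely again only a limit is reported.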

Compound 4, half-maximal cytotoxic concentration: > 100000 nM
Compound 4 ended at the assay's limit (the forecaster's own chance of this, stated with the estimate: 70%); the middle value lies on the limit itself.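

Among these compounds, compound 3 and compound 4 both stand at a limit of this assay, not at numbers, and no step between them can be read: the limit of > 100000 nM in this assay, at which 2 of the 4 values shown sit. The compounds shown leave open whether fluoro in place of methyl on an aromatic carbon changes the read-out at all on the core of compound 3.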